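From a 2-fluorophenyl amine to a 4-methoxyphenyl amine

A few compounds are considered here, and "the series" means these few. Any claim that something is new, unique, unknown or untested is made for them only; others in the source may bear on it.

Of the compounds shown here, three sharing one core have been measured in an in vitro assay on HEK-tsA201 cells for antagonist activity at Neuronal acetylcholine receptor; alpha3/beta4 (Homo sapiens), read by fluorescence and calcium flux; a lower number here means a stronger inhibitor, a higher number a weaker inhibitor. Compound 1 `CCCOc1ccc(C(=O)Nc2cccc(Br)n2)cc1` gives only a limit of the assay, > 100000 nM. Compound 2 `CCCOc1ccc(C(=O)Nc2cccc(CC)n2)cc1` gives 29200 nM in this assay. Compound 3 `CCCOc1ccc(C(=O)Nc2cccc(Nc3ccccc3F)n2)cc1` likewise reaches only a limit, > 100000 nM. Within the data shown here, the step of an at least 3.4-fold lower number from compound 1 to compound 2 (0.53 log units; beyond the scatter) is the one readable change; the step of an at least 3.4-fold higher number from compound 2 to compound 3 (0.53 log units; beyond the scatter) runs the other way, and the step that the two limits leave unreadable from compound 1 to compound 3 cannot be sized. Compound 3 therefore stands at the weak end of what has been shown, sitting at the limit of > 100000 nM in this assay, at which 2 of the 3 values shown sit, together with compound 1.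

Compound 4 `CCCOc1ccc(C(=O)Nc2cccc(Nc3ccc(OC)cc3)n2)cc1` differs from compound 3 in one place: 4-methoxyphenyl in place of 2-fluorophenyl on a nitrogen on an aromatic ring. Among the measured compounds shown here, no measured step covers a change within the arylamino group, so the expectation rests on compound 3 alone, and the step that the estimate means, a number no higher from compound 3 to compound 4 (the limit leaves the size open), is expected to stay within the scatter. Compound 4 is expected to give roughly 100000 nM, between 30000 nM and 300000 nM, and most probably this assay will again report only a limit for it.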

Compound 4, half-maximal inhibitory concentration: > 100000 nM
Compound 4: no number, only a limit (the forecaster's own chance of this, stated with the estimate: 70%); the middle value sits exactly at the limit.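

With (4-methoxyphenyl)amino on this aromatic carbon, compound 4 also ends at a limit of this assay, not at a number, so a second arylamino group joins compound 3 there: the limit of > 100000 nM in this assay, at which 3 of the 4 values shown sit.

Set against the ethyl of compound 2, this group gives an at least 3.4-fold higher number from compound 2 to compound 4 (0.53 log units; beyond the scatter), so two different arylamino groups now stand on the weak side of compound 2, where the earlier compounds offered only one. The steps that link compound 4 to compound 3 and to compound 1 cannot be read, since limits stand at both ends, and 4-methoxyphenyl and 2-fluorophenyl cannot be ranked against each other.

Compound 2 alone gives a number, so this position is read through ethyl only. From the compounds shown here alone, whether a methyl, a longer chain such as propyl, or an unsubstituted amine on this carbon would give a number remains open.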